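The compounds below may be only part of what the source reports. "The series", "measured", "known", "first", "only" and "open" are said of these compounds alone.

Measured in a functional assay on HepG2 cells (Homo sapiens) for antiproliferative activity, read by MTT assay, with a stated time of 48 h; on this read-out lower numbers stand for stronger inhibition and higher numbers for weaker inhibition:
- Compound 1 `COc1ccc(N(C)c2ccnc(Cl)n2)cc1OCCBr`: 7720 nM
- Compound 2 `COc1ccc(N(C)c2ccnc(Cl)n2)cc1OCCCCBr`: 168 nM
- Compound 3 `COc1ccc(N(C)c2cc(C)nc(C)n2)cc1`: 824 nM

Among these three, compound 3 takes the middle place at 824 nM. Compound 2 lies lower and compound 1 higher, both by more than the usual scatter.

The next compound, compound 4 `COc1ccc(N(C)c2cc(C)nc(C)n2)cc1O`, differs from compound 3 by a single change: hydroxy in place of hydrogen on an aromatic carbon. A hydroxy replaces hydrogen on an aromatic carbon, ortho to a methoxy group.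

Among the compounds with values here, only one measured step comes near this change: a 46-fold lower number from compound 1 to compound 2 (1.66 log units; beyond the scatter). That step is large and shows that the number can move strongly when the chain on an oxygen at an aromatic ring changes. It is not a direct guide, however. It compares two chains, whereas the new change adds a hydroxy where there was only hydrogen, and the two compounds in that step also carry a different core substitution. Within the data shown here, no measured pair shows the effect of a free hydroxy.

In this assay, therefore, no step beyond the scatter is expected, and no firm direction can be assigned. The estimated change is a 1.4-fold lower number from compound 3 to compound 4 (0.14 log units; within the scatter), a shift expected to stay within the scatter. The uncertainty remains wide. For compound 4 the expected value is 600 nM, with an estimated range from 150 nM to 2500 nM.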

Compound 4, half-maximal inhibitory concentration: 112 nM
Beside the measured number, compound 4's estimate is 5.4-fold (0.73 log units) above it, and the stated range ends above it.
By their numbers in this assay, from the lowest: compounds 4 and 2 (each within the scatter of the next); then compound 3; then compound 1.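

In this assay, within the data shown here, the single change of hydroxy in place of hydrogen on an aromatic carbon, ortho to a methoxy group and meta to a large group, gives a 7.4-fold lower number from compound 3 to compound 4 (0.87 log units; beyond the scatter) and so shows that this carbon does not tolerate substitution neutrally, since a single added oxygen moves the number beyond the scatter toward stronger inhibition. Among these compounds, the earlier compounds carried either hydrogen or an oxygen bearing a chain at this carbon, and the one step among them, a 46-fold lower number from compound 1 to compound 2 (1.66 log units; beyond the scatter) in the same assay, compared two chains and gave no reading of a free hydroxy against hydrogen, which this pair now supplies on the shared core of compound 3 and compound 4. Nothing measured here accounts for the size or direction of this step.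

The compounds shown leave open whether the effect belongs to the hydroxy itself, as an amine, a fluorine atom or a second methoxy at the same carbon would test. They also leave open whether a free hydroxy would give a similar step on the core of compound 1, which carries a chlorine atom on the other ring.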